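Capping the ring amine of compound 1

The compounds below may be only part of what the source reports. "The series", "measured", "known", "first", "only" and "open" are said of these compounds alone.

Compound 1 (`c1ccc(Oc2ccc(-c3cc(N4CCNCC4)[nH]n3)cc2)cc1`) and compound 2 (`c1ccc(Oc2ccc(-c3cc(C4CCOCC4)[nH]n3)cc2)cc1`) share a core and differ in a single group. Among the compounds with values here, in an ADME assay on L6 cells (Rattus norvegicus) for cytotoxicity (a lower number here means a stronger inhibitor, a higher number a weaker inhibitor), compound 1 gives 18000 nM, the lower of the two numbers measured so far. Compound 2 gives 89600 nM, so compound 1 is the more cytotoxic of the pair.

Compound 3 (`CC(C)(C)OC(=O)N1CCN(c2cc(-c3ccc(Oc4ccccc4)cc3)n[nH]2)CC1`) keeps the core of compound 1 and changes it in one place, with tert-butoxycarbonyl in place of hydrogen on an amine nitrogen in a ring.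

Within the data shown here, only one measured step offers any guide, and it is an imperfect one. Replacing piperazin-1-yl with oxan-4-yl on an aromatic carbon gave a 5.0-fold higher number from compound 1 to compound 2 (0.70 log units; beyond the scatter). That step also removes the amine hydrogen of compound 1, as the new change does, but it swaps the whole ring, whereas compound 3 keeps it and adds a larger group. With so little evidence, a smaller move in the same direction seems the most reasonable expectation in this assay, an estimated 2.2-fold higher number from compound 1 to compound 3 (0.35 log units; beyond the scatter). Compound 3 is therefore expected to give about 40000 nM, with an estimated range of 13000 nM to 110000 nM.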

Compound 3, half-maximal inhibitory concentration: 30000 nM
Beside the measured number, compound 3's estimate is 1.3-fold (0.12 log units) above it; low and high end bracket the measured number.
By their numbers in this assay, from the lowest: compounds 1 and 3 (each within the scatter of the next); then compound 2.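

Adding tert-butoxycarbonyl to the amine nitrogen in the ring gives a 1.7-fold higher number from compound 1 to compound 3 (0.22 log units; within the scatter) in this assay, so this group of 7 heavy atoms can replace the hydrogen there without a difference that can be told from scatter. This shows that, in this assay, removing the hydrogen from that nitrogen while keeping the ring does not by itself produce a clear shift. The earlier step, a 5.0-fold higher number from compound 1 to compound 2 (0.70 log units; beyond the scatter), exchanged the whole piperazin-1-yl group for oxan-4-yl and lay beyond the scatter, but the new result cannot say which part of that exchange mattered, and no measurement is available to explain either result.

Still open, from the compounds shown here alone, is whether other groups on this nitrogen, such as a methyl, an acetyl or a longer chain ending in a carboxylic acid, would also stay within the scatter of compound 1 or would move the number clearly. A single capped compound also leaves open whether tert-butoxycarbonyl would behave in the same way on a different core, so this result applies only to the core of compound 1.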